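Methoxy to trifluoromethyl on two oxadiazole-amine cores

The source may report more compounds than this note shows. Statements on the series, on what has been measured and on what is new or still open speak of the compounds shown alone.

Measured so far:
compound 1 `C#CCN(c1nc(-c2ccc(OC)cc2)no1)C1CCCCC1` — 72.5 ug/mL
compound 2 `COc1ccc(-c2noc(N(Cc3cn(C[C@H](CO[C@@H]4C=C[C@H](OC(C)=O)[C@@H](COC(C)=O)O4)OC(C)=O)nn3)C3CCCCC3)n2)cc1` — 141 ug/mL
compound 3 `C#CCN(c1nc(-c2ccc(C(F)(F)F)cc2)no1)C1CCCCC1` — 61.9 ug/mL

In an ADME assay on HepG2 cells (Homo sapiens) for cytotoxicity, read by MTT assay, with a stated time of 48 h (on this read-out lower numbers stand for higher toxicity in this test and higher numbers for lower toxicity in this test), compound 1 gives 72.5 ug/mL and compound 3 gives 61.9 ug/mL; the change trifluoromethyl in place of methoxy on an aromatic carbon gave a 1.2-fold lower number from compound 1 to compound 3 (0.07 log units; within the scatter). Compound 2 gives 141 ug/mL; the difference between its core and that of compound 1 is not broken down here. Compound 4 `CC(=O)OC[C@H]1O[C@H](OC[C@@H](Cn2cc(CN(c3nc(-c4ccc(C(F)(F)F)cc4)no3)C3CCCCC3)nn2)OC(C)=O)C=C[C@@H]1OC(C)=O` is not yet measured. It carries the same kind of change, (trifluoromethyl in place of methoxy on an aromatic carbon), read one bond further out as 4-methoxyphenyl to 4-(trifluoromethyl)phenyl. Because the earlier step of a 1.2-fold lower number from compound 1 to compound 3 (0.07 log units; within the scatter) stayed within the scatter, compound 4 is expected to sit close to compound 2, a step of a 1.2-fold lower number from compound 2 to compound 4 (0.07 log units; within the scatter). The estimate for compound 4 is 120 ug/mL, expected between 60 ug/mL and 240 ug/mL.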

Compound 4, half-maximal cytotoxic concentration: 81.4 ug/mL
The estimate for compound 4 lay 1.5-fold (0.17 log units) above the measured number; measured number inside the range.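

In this assay trifluoromethyl in place of methoxy on an aromatic carbon gives a 1.7-fold lower number from compound 2 to compound 4 (0.24 log units; within the scatter) and the two cores agree within the scatter: the same change on two cores in this assay, a 1.2-fold lower number (0.07 log units; within the scatter) from compound 1 to compound 3 and a 1.7-fold lower number (0.24 log units; within the scatter) from compound 2 to compound 4, 1.5-fold (0.17 log units) apart, within the scatter of two such steps. Across these two cores, the change therefore carries over without a difference that can be told apart, and neither step moves the number beyond the scatter. This rests on two pairs in one assay, so it does not show that the change would read the same on a further core, nor why the numbers fall as they do.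

On these data alone, whether an amine or a carboxylic acid in place of methoxy on that aromatic carbon would behave alike stays open. Also open, as far as these compounds go, is how the cores themselves contribute, as the difference between them is not broken down.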